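A few compounds are considered here, and "the series" means these few. Any claim that something is new, unique, unknown or untested is made for them only; others in the source may bear on it.

Series notes on the pyrrolidine and pyrrole acids against NOTUM.

Compound 1 `O=C(O)C1CCN(c2ccccc2)C1` is the simplest member. In an assay on cells for inhibition of Palmitoleoyl-protein carboxylesterase NOTUM variant C330S (Homo sapiens), read by fluorescence, with a stated time of 40 min (on this read-out higher numbers stand for weaker inhibition and lower numbers for stronger inhibition), compound 1 gives 48000 nM. Compound 2 `O=C(O)C1CCN(c2ccccc2Cl)C1` carries chloro in place of hydrogen on an aromatic carbon relative to compound 1, and in this assay compound 2 gives 19000 nM, so the step of a 2.5-fold lower number from compound 1 to compound 2 (0.40 log units; beyond the scatter) is a modest gain.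

Compound 3 `Cc1cc(C(=O)O)c(C)n1-c1ccccc1Cl` sits on a different core; the difference between the core of compound 3 and the core of compound 1 is not broken down here. In this assay compound 3 gives 2300 nM, the lowest number of the three measured compounds, and the gap to compound 2 and to compound 1 is beyond the scatter in both cases.

Compound 4 `Cc1cc(C(=O)O)c(C)n1-c1c(Cl)cccc1Cl` is not yet measured. It differs from compound 3 by chloro in place of hydrogen on an aromatic carbon. This is the same kind of change as that from compound 1 to compound 2, though not the same: in compound 2 the entering chloro sits ortho to a group of 8 heavy atoms, whereas in compound 4 it sits ortho to a large group and meta to a chloro group (1 heavy atom). For the measured compounds named here, the only measured precedent, a 2.5-fold lower number from compound 1 to compound 2 (0.40 log units; beyond the scatter), argues for a modest further lowering of the number. For compound 4 in this assay a step of a 2.1-fold lower number from compound 3 to compound 4 (0.32 log units; beyond the scatter) is expected, resting on that single precedent and on the absence of any second example. Compound 4 is therefore estimated at 1100 nM, with a plausible range from 400 nM to 3500 nM.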

Compound 4, half-maximal inhibitory concentration: 2300 nM
Estimate against measurement, compound 4: 2.1-fold (0.32 log units) below; the range from low to high includes it.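

In this assay, chloro in place of hydrogen on an aromatic carbon gives no change at the digits printed from compound 3 to compound 4 (within the scatter), whereas the same change on the earlier core gives a 2.5-fold lower number from compound 1 to compound 2 (0.40 log units; beyond the scatter), a modest step beyond the scatter. Set side by side, the two steps cannot be told apart: the same change on two cores in this assay, a 2.5-fold lower number (0.40 log units; beyond the scatter) from compound 1 to compound 2 and no change at the digits printed (within the scatter) from compound 3 to compound 4, 2.5-fold (0.40 log units) apart, within the scatter of two such steps This pair gives no ground for calling the change dependent on the core, but it does not show that the change carries over unaltered either, as it rests on only two steps and the chloro enters a different setting in compound 4, ortho to a large group and meta to a chloro group.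

The compounds shown leave open how the number on the core of compound 3 would respond to a group other than chloro on the six-membered aromatic ring, such as a methoxy group, a nitrile or a trifluoromethyl group. They also leave open what would follow if an amide stood in place of the carboxylic acid, or if an ethyl group stood in place of either methyl group on the core.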